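The source may hold more compounds than are shown below. What is called first, only, known or untested is meant among the compounds shown, and "the series" means these compounds.

Compound 1 `COc1cc(OC)c(-c2coc3cc(OCC=C(C)C)ccc3c2=O)cc1OC` and compound 2 `COc1cc(OC)c(-c2coc3cc(OCc4ccccc4)ccc3c2=O)cc1OC` share one core and differ only in the group on a saturated chain carbon bound to an oxygen on an aromatic ring. In a functional assay on U-251 cells (Homo sapiens) for antiproliferative activity, read by MTT assay, with a stated time of 24 h (on this read-out lower numbers stand for stronger inhibition and higher numbers for weaker inhibition), compound 1 gives 3500 nM, the lowest of the two numbers, while compound 2 gives 6750 nM. For the measured compounds named here, the step of a 1.9-fold higher number from compound 1 to compound 2 (0.29 log units; within the scatter) is the only measured comparison, and it lies within the scatter. Compound 3 `COc1cc(OC)c(-c2coc3cc(OCc4ccc(C(F)(F)F)cc4)ccc3c2=O)cc1OC` is not yet measured; it carries 4-(trifluoromethyl)phenyl in place of 2-methylprop-1-en-1-yl on a saturated chain carbon bound to an oxygen on an aromatic ring. Going by the values given here, this change resembles the one from compound 1 to compound 2, which brought a 1.9-fold higher number from compound 1 to compound 2 (0.29 log units; within the scatter), so little movement beyond the scatter is expected, perhaps a small shift toward weaker inhibition. For compound 3 the expected step is a 1.7-fold higher number from compound 1 to compound 3 (0.23 log units; within the scatter). Compound 3 is therefore estimated at 6000 nM, with a likely range from 2500 nM to 14000 nM.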

Compound 3, half-maximal inhibitory concentration: 3750 nM
For compound 3 the middle estimate is 1.6-fold (0.20 log units) above the measured one, within the range that was stated.
By their numbers in this assay, from the lowest: compounds 1, 3 and 2 (each within the scatter of the next).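

In this assay, the exchange of 3-methylbut-2-en-1-yl for 4-(trifluoromethyl)benzyl gives (a 1.1-fold higher number from compound 1 to compound 3 (0.03 log units; within the scatter)), and trifluoromethyl in place of hydrogen on an aromatic carbon gives (a 1.8-fold lower number from compound 2 to compound 3 (0.26 log units; within the scatter)). The earlier pair offered only one aromatic replacement, whereas these steps show that a larger aromatic group carrying trifluoromethyl also stays within the scatter of both the 3-methylbut-2-en-1-yl and benzyl compounds, so the three compounds cannot be told apart in this read-out. Nothing measured here bears on what lies behind these numbers.

As far as these compounds go, it remains open whether any group at this place can move the number beyond the scatter. An amine, a carboxylic acid or a longer chain on the saturated chain carbon bound to an oxygen on an aromatic ring would be a wider test than the three groups shown.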